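A few compounds are considered here, and "the series" means these few. Any claim that something is new, unique, unknown or untested is made for them only; others in the source may bear on it.

The measured compounds:
compound 1 `Cc1ccc(S(=O)(=O)NCc2ccc(CNC(=O)c3ccccc3)cc2)cc1`: > 1000 nM
compound 2 `O=C(NCc1ccc(CNS(=O)(=O)c2ccccc2)cc1)c1ccncc1`: 10 nM
compound 3 `O=C(NCc1ccc(CNS(=O)(=O)c2ccccc2)cc1)c1ccccc1`: 1 nM

In an assay on MDA-MB-231 cells for binding affinity to C-X-C chemokine receptor type 4 (Homo sapiens), read by immunofluorescence and microscopy, with stated times of 10 min and 30 min (on this read-out higher numbers stand for an effect only at larger amounts of compound and lower numbers for an effect already at smaller amounts), compound 3 gives 1 nM and compound 2 gives 10 nM. Compound 1 gives only a limit of the assay, > 1000 nM, not a number. Compound 1 thus stands at the edge of what this assay reports (the limit of > 1000 nM in this assay, at which 1 of the 3 values shown sits), with no measured value of its own. Two steps are known. The first is an at least 1000-fold lower number from compound 1 to compound 3 (3.00 log units; beyond the scatter), a large one, reached by hydrogen in place of methyl on an aromatic carbon. The second is a 10-fold lower number from compound 2 to compound 3 (1.00 log units; beyond the scatter), a modest one, reached by phenyl in place of pyridin-4-yl on a carbonyl carbon.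

Compound 4 `Cc1ccc(S(=O)(=O)NCc2ccc(CNC(=O)c3ccccc3Cl)cc2)cc1` differs from compound 1 by chloro in place of hydrogen on an aromatic carbon, placed on the benzoyl ring, ortho to a large group. Going by the values given here, neither measured step touches that ring in this way, so no step bears directly on the change. What the steps do show is that the methyl, which compound 4 keeps, sits on the side of compound 1 that gives only a limit. The step that the limit leaves unreadable from compound 1 to compound 4 is therefore expected to stay within the scatter, with the limit likely to recur. Compound 4 is estimated at 2000 nM, in the range 300 nM to 10000 nM.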

Compound 4, effective concentration (reported as EC, without a stated level of effect): 10 nM
Compound 4: the middle estimate sits 200-fold (2.30 log units) above what was measured; measured number below the stated range.
By their numbers in this assay, from the lowest: compound 3; then compounds 2 and 4 (each within the scatter of the next). At a limit, above all of these: compound 1.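

In this assay, chloro in place of hydrogen on an aromatic carbon of the benzoyl ring, ortho to a large group, gives an at least 100-fold lower number from compound 1 to compound 4 (2.00 log units; beyond the scatter), so this place, which neither earlier step touched, responds strongly to the addition of one chlorine atom. Going by these compounds alone, compound 4 keeps the methyl, so replacing that methyl with hydrogen is not the only single change that takes compound 1 to a measured number: a change on the benzoyl ring alone does so too. The full size of this step cannot be read, because the value for compound 1 is a limit and not a number: the limit of > 1000 nM in this assay, at which 1 of the 4 values shown sits.

The compounds shown leave open whether chloro at this place would also lower the number on the core of compound 3, which carries hydrogen where compound 4 carries the methyl, or whether the two changes would fail to add up. They also leave open whether the result is particular to chloro, since fluoro, bromo, methoxy or an amine at the same place, and chloro elsewhere on the ring, are not among them.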